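This account rests on a few compounds, and the source may have more. Where it says the series, first, only, none or still open, it means among the compounds named here.

Compound 1 `OC[C@H]1O[C@@H](CNCc2ccccc2)[C@H](O)[C@@H](O)[C@@H]1O` is the weaker of the two measured compounds: in an assay on isolated protein for inhibition of lysosomal alpha-glucosidase (Rattus norvegicus), with stated times of 15 min and 60 min (a higher number here means a weaker inhibitor, a lower number a stronger inhibitor), compound 1 gives 1330000 nM, the highest number among the two, while compound 2 `OC[C@H]1O[C@@H](CNCc2ccc(Cl)c(Cl)c2)[C@H](O)[C@@H](O)[C@@H]1O` gives 221000 nM, a number lower by a margin beyond the scatter. Among the compounds with values here, no step between measured compounds is recorded, so the effect of a single change on the benzyl ring is not known from the data. Compound 3 `OC[C@H]1O[C@@H](CNCc2ccc(F)cc2)[C@H](O)[C@@H](O)[C@@H]1O` differs from compound 1 by fluoro in place of hydrogen on an aromatic carbon, on an aromatic carbon of a six-membered aromatic ring of carbon only, para to a large group; the same difference, cut one bond further out, reads phenyl to 4-fluorophenyl. A small step downward is expected, since compound 2 with its 221000 nM shows that halogen substitution on this ring can lower the number. For compound 3 the expected value in this assay is 600000 nM, with a range from 250000 nM to 1500000 nM, corresponding to an estimated step of a 2.2-fold lower number from compound 1 to compound 3 (0.35 log units; beyond the scatter).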

Compound 3, half-maximal inhibitory concentration: 203000 nM
Compound 3: the middle estimate sits 3.0-fold (0.47 log units) above what was measured, and the stated range ends above it.
By their numbers in this assay, from the lowest: compounds 3 and 2 (each within the scatter of the next); then compound 1.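

In this assay, within the data shown here, fluoro in place of hydrogen on an aromatic carbon, para to a large group, gives a 6.6-fold lower number from compound 1 to compound 3 (0.82 log units; beyond the scatter) and is the first change at a single place that can be read. It shows that this one added fluorine atom is enough on its own to lower the number on the shared core, something the two earlier compounds, which differ in more than one place, could not show. Nothing measured here accounts for the size of this step.

From the compounds shown here alone, it remains open whether a single chloro, a methoxy, a trifluoromethyl or a carboxylic acid in the same place would lower the number as well. Also open, going by these compounds, is whether fluoro on another carbon of the ring would give a similar step.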